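This account rests on a few compounds, and the source may have more. Where it says the series, first, only, none or still open, it means among the compounds named here.

Compound 1 `CCOC(=O)c1c(C)nc(-c2cccc(C#N)c2)n1C` gives 22100 nM in a functional assay on a cell-free system (plasma, Oryctolagus cuniculus) for inhibition, with stated times of 5 min, 1 min and 6 min (on this read-out lower numbers stand for stronger inhibition and higher numbers for weaker inhibition), the highest of the two numbers recorded. Compound 2 `CCOC(=O)c1c(C)nc(-c2cccc(C#N)c2)n1C(C)C`, which carries isopropyl in place of methyl on an aromatic nitrogen, gives 9260 nM in this assay, so a 2.4-fold lower number from compound 1 to compound 2 (0.38 log units; beyond the scatter). Compound 3 `CCOC(=O)c1c(C)nc(-c2cccc(C#N)c2)n1OCc1cccc(Cl)c1` differs from compound 1 by (3-chlorobenzyl)oxy in place of methyl on an aromatic nitrogen. Among the measured compounds shown here, only the step from compound 1 to compound 2 bears on a replacement at this aromatic nitrogen, and it was modest. A fall of similar or somewhat greater size is expected, though with wide uncertainty. Compound 3 is therefore estimated at 6000 nM in this assay, between 1500 nM and 25000 nM. The expected step is a 3.7-fold lower number from compound 1 to compound 3 (0.57 log units; beyond the scatter).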

Compound 3, half-maximal inhibitory concentration: 19400 nM
For compound 3 the middle estimate is 3.2-fold (0.51 log units) below the measured one; measured number inside the range.
By their numbers in this assay, from the lowest: compound 2; then compounds 3 and 1 (each within the scatter of the next).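

In this assay, (3-chlorobenzyl)oxy on this aromatic nitrogen cannot be told apart from methyl, with a 1.1-fold lower number from compound 1 to compound 3 (0.06 log units; within the scatter). Set against isopropyl it gives a 2.1-fold higher number from compound 2 to compound 3 (0.32 log units; beyond the scatter), so the lower number seen with isopropyl does not extend to every group with more heavy atoms than methyl. No evidence is available to explain this difference between the two groups. On these data alone, whether the aromatic ring or the oxygen link separates (3-chlorobenzyl)oxy from isopropyl stays open. So does how a plain benzyl, cyclopropyl or tert-butyl group would read at this nitrogen.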